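This account rests on a few compounds, and the source may have more. Where it says the series, first, only, none or still open, it means among the compounds named here.

Of the compounds shown here, three have so far been tested in a functional assay on BGC-823 cells (Homo sapiens) for antiproliferative activity, read by MTT assay, tested at 1 uM; a lower number here means a weaker effect, a higher number a stronger effect of the compound at the concentration tested. Compound 1 `COc1cc(C(=O)N/N=C/c2ccccc2F)cc(OC)c1OC` gives 51.6%. A close relative built on the same open-chain core as compound 1 is compound 2 `COc1ccc(/C=N/NC(=O)c2cc(OC)c(OC)c(OC)c2)c(OC)c1`, which gives -6.9%. Compound 3 `COc1cc(C2=NN(C(C)=O)C(c3ccc(F)c(F)c3)O2)cc(OC)c1OC`, in which that core is closed into a five-membered ring bearing an acetyl group, gives 18.3% in this assay. This places compound 3 second highest of the three numbers: its nearest neighbour is compound 2, whose number lies lower by a margin beyond the usual scatter, and its furthest is compound 1, whose number lies higher, again beyond the scatter.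

Compound 4 `COc1ccc(OC)c(C2OC(c3cc(OC)c(OC)c(OC)c3)=NN2C(C)=O)c1` has not yet been measured in this assay. It differs from compound 3 in one place: 2,5-dimethoxyphenyl in place of 3,4-difluorophenyl on a saturated ring carbon. Within the data shown here, no pair of measured compounds differs in exactly this way, so there is no measured step to lean on. The closest hint is that compound 1 with 51.6% stands well above compound 2 with -6.9%, and those two differ in the groups on one ring in a way that loosely resembles the present change, though not in a single step. On that basis the step of a number 13.3 percentage points lower from compound 3 to compound 4 (beyond the scatter) is expected to be a modest move downward, possibly no larger than the scatter. Compound 4 is therefore estimated to give 5% in this assay, with a range from -15% to 30%.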

Compound 4, a percentage reported as inhibition, at one concentration (the size of the read-out at that concentration, not a potency): 0.4%
Compound 4: middle estimate off by 4.6 percentage points, on the high side; low and high end bracket the measured number.
By their numbers in this assay, from the lowest: compounds 2 and 4 (each within the scatter of the next); then compound 3; then compound 1.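

Among these compounds, compound 3 and compound 4 form the first pair here that differs in only one place, so they give the first direct reading of this position. In this assay, putting 2,5-dimethoxyphenyl in place of 3,4-difluorophenyl on the saturated ring carbon gives a number 17.9 percentage points lower from compound 3 to compound 4 (beyond the scatter), which shows that the read-out responds to the group held at this carbon. The entering group brings two methoxy groups, which count as hydrogen-bond acceptors, while the leaving group brings two fluorine atoms and no acceptors, but nothing measured here explains why the number falls.

This single step changes both the kind of group on the phenyl ring and the numbering of its positions, so the compounds shown leave open which of the two matters. They also leave open how this carbon would respond to a phenyl ring carrying an amine or a carboxylic acid, or to a longer alkyl chain in place of the ring.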